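Phenyl to pyridin-2-yl: working notes on compound 3

The compounds below may be only part of what the source reports. "The series", "measured", "known", "first", "only" and "open" are said of these compounds alone.

Measured in a functional assay on A-427 cells (Homo sapiens) for cytotoxicity, read by colorimetric assay and MTT assay; a higher number here means a weaker inhibitor, a lower number a stronger inhibitor:
- compound 1 `COc1ccc(-c2cc3c(OC)cc(OC)cc3n(CC#N)c2=O)cc1`: 10000 nM
- compound 2 `COc1ccc(-c2cc3c(OC)cc(OC)cc3n(C)/c2=N\Nc2ccccc2)cc1`: 10000 nM

Level with compound 1, compound 2 gives 10000 nM, within the scatter. Compound 3 `COc1ccc(-c2cc3c(OC)cc(OC)cc3n(C)/c2=N\Nc2ccccn2)cc1` differs from compound 2 in one place, with pyridin-2-yl in place of phenyl on an amine nitrogen. Among the measured compounds shown here, no measured step covers this change. A small move toward stronger inhibition in this assay is expected, hardly beyond the scatter. The estimated change is a 1.7-fold lower number from compound 2 to compound 3 (0.22 log units; within the scatter). Compound 3 is expected at 6000 nM, with an estimated range of 1500 nM to 12000 nM.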

Compound 3, half-maximal inhibitory concentration: 10000 nM
For compound 3 the middle estimate is 1.7-fold (0.22 log units) below the measured one, and the stated range covers the measured number.
By their numbers in this assay, from the lowest: compounds 1, 2 and 3 (each within the scatter of the next).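

Pyridin-2-yl in place of phenyl on the amine nitrogen gives no change at the digits printed from compound 2 to compound 3 (within the scatter) in this assay, the only single-place comparison in the series so far. At this position, then, the swap of a carbon-only ring for one with a hydrogen-bond acceptor leaves the read-out level. No supporting measurement bears on this result.

On these data alone, whether a carboxylic acid-bearing phenyl or a longer alkyl chain on that amine nitrogen would move the number away from compound 2 at 10000 nM remains open.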